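The source may report more compounds than this note shows. Statements on the series, on what has been measured and on what is new or still open speak of the compounds shown alone.

Values measured in a toxicity assay on Vero cells (Chlorocebus sabaeus) for cytotoxicity, read by MTT assay, with a stated time of 72 h; a lower number here means a stronger inhibitor, a higher number a weaker inhibitor:
- Compound 1 `COc1ccc(C(=O)n2c(C(C)C)nc3ccccc32)cc1`: > 10000 nM, a limit of the assay
- Compound 2 `COc1ccc(C(=O)n2c(C3CCCCC3)nc3ccccc32)cc1`: 1640 nM

Among the measured compounds shown here, compound 2 holds the only exact number in this assay, and the entry for compound 1 is only a limit. Compound 3 `COc1ccc(C(=O)n2c(C3CCCC3)nc3ccccc32)cc1` has cyclopentyl in place of cyclohexyl on an aromatic carbon. For the measured compounds named here, the single measured step at this place, cyclohexyl in place of isopropyl, was an at least 6.0-fold lower number from compound 1 to compound 2 (0.78 log units; beyond the scatter), beyond the scatter. Removing part of the cyclohexyl group might undo some of that step, so a higher number is expected. The expected step is a 1.8-fold higher number from compound 2 to compound 3 (0.26 log units; within the scatter). Compound 3 is estimated at 3000 nM, with an expected range of 1300 nM to 8000 nM.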

Compound 3, half-maximal inhibitory concentration: > 10000 nM
Compound 3: no number, only a limit; the forecaster's own chance of this, stated with the estimate: 15%; middle value at least 3.3-fold (0.52 log units) from the limit.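

In this assay, cyclopentyl in place of cyclohexyl gives an at least 6.0-fold higher number from compound 2 to compound 3 (0.78 log units; beyond the scatter), so the lower number of compound 2 does not carry over to the slightly smaller ring at this position. The entry for compound 3 is a limit and not a number, and the step between compound 1 and compound 3 cannot be read. Of the groups shown at this aromatic carbon, only cyclohexyl gives an exact number: the limit of > 10000 nM in this assay, at which 2 of the 3 values shown sit.

Going by these compounds, whether a cycloheptyl or phenyl group, or an amine, would give an exact number here remains open. So do the true values of compound 1 and compound 3.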